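Working notes on a sulfamoyl change in the shared core series

The compounds below may be only part of what the source reports. "The series", "measured", "known", "first", "only" and "open" are said of these compounds alone.

Compound 1 `CCOC(=O)[C@@H]1CCCN(S(=O)(=O)c2ccc(S(=O)(=O)N(CC)C(C)C)cc2)C1` is measured in a functional assay on MIA PaCa-2 cells (Homo sapiens) for inhibition, read by MTT assay, with a stated time of 7 days (on this read-out lower numbers stand for stronger inhibition and higher numbers for weaker inhibition), where it gives 1000 nM. On the numbers at hand compound 1 sits level with compound 2 `CC(C)c1noc(N2CCN(C(=O)[C@@H]3CCCN(S(=O)(=O)c4ccc(S(=O)(=O)NC5CC5)cc4)C3)CC2)n1`, which gives 1000 nM in this assay; the two are not separated at the digits shown and together stand as the highest numbers of the three. Compound 3 `CCN(CC)S(=O)(=O)c1ccc(S(=O)(=O)N2CCC[C@@H](C(=O)N[C@H]3CCN(C(=O)OC(C)(C)C)C3)C2)cc1` gives 100 nM in this assay, a lower number than that of compound 1 by a gap that lies beyond the scatter. Among the compounds with values here, compound 3 differs from compound 1 in more than one place, so no single step is set out for that pair, and only what the two values show is noted here.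

Compound 4 `CCCN(CCC)S(=O)(=O)c1ccc(S(=O)(=O)N2CCC[C@@H](C(=O)OCC)C2)cc1` has not yet been measured in this assay. It differs from compound 1 in one place: dipropylamino in place of ethyl(isopropyl)amino on a sulfonyl sulfur. Within the data shown here, no measured pair in the set isolates a change of this kind on the sulfonyl sulfur, so the step from compound 1 to compound 4 is expected to be small, in either direction or none beyond the scatter. The estimate sets this expected step at a 1.1-fold lower number from compound 1 to compound 4 (0.05 log units; within the scatter). Compound 4 is expected to give about 900 nM in this assay, with a range from 300 nM to 3000 nM.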

Compound 4, half-maximal inhibitory concentration: 2300 nM
The estimate for compound 4 lay 2.6-fold (0.41 log units) below the measured number; the measured number falls inside the stated range.
By their numbers in this assay, from the lowest: compound 3; then compounds 1 and 2 (each within the scatter of the next); then compound 4.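

Within the data shown here, this is the first single-place step in the set: in this assay, dipropylamino in place of ethyl(isopropyl)amino on a sulfonyl sulfur gives a 2.3-fold higher number from compound 1 to compound 4 (0.36 log units; beyond the scatter). The read-out therefore separates these two open-chain groups at this position, although neither carries a ring, a hydrogen-bond donor or a hydrogen-bond acceptor, and they differ by only one heavy atom in the printed count. Nothing at hand gives a reason for the step.

A single pair cannot show whether the higher number goes with the loss of the branched isopropyl group, the longer propyl chains or the larger group as a whole, and dibutylamino or bis(2-methoxyethyl)amino on the sulfonyl sulfur of the core of compound 1 would extend the comparison beyond this one change. Among these compounds, it also remains open whether the same exchange would give a step of similar size and direction with the amide-bearing side chains of compound 2 and compound 3, as no single-place pair in the set carries this change on either of those compounds.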